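Methyl to Methoxy: An Estimate for Compound 4

A few compounds are considered here, and "the series" means these few. Any claim that something is new, unique, unknown or untested is made for them only; others in the source may bear on it.

In a functional assay on B16 cells (Mus musculus) for inhibition, with a stated time of 72 h (a lower number here means a stronger inhibitor, a higher number a weaker inhibitor), compound 1 `S=C1NCCN1Cc1ccccc1` gives > 10000 nM. That value is a limit of the assay and not a number. Compound 2 `S=C1NCCN1Cc1ccc(Cl)cc1` carries chloro in place of hydrogen on an aromatic carbon and gives 4300 nM. The size of this change is an at least 2.3-fold lower number from compound 1 to compound 2 (0.36 log units; beyond the scatter).

Compound 3 `Cc1ccc(CN2CCCNC2=S)cc1` has a core of its own and a methyl group on its aromatic ring. Compound 3 gives 5100 nM, which lies within the scatter of the value for compound 2.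

Compound 4 `COc1ccc(CN2CCCNC2=S)cc1` keeps the core of compound 3 but has methoxy in place of methyl on an aromatic carbon.

For the measured compounds named here, no measured pair makes this exact swap. Going by the values given here, the only measured step, an at least 2.3-fold lower number from compound 1 to compound 2 (0.36 log units; beyond the scatter), offers weak guidance: it involves a different group on a different core, and it starts from a limit. It shows that a change on the ring can matter, but it gives neither a size nor a direction for this swap. Compound 3, at 5100 nM, is therefore the best starting point, and no change beyond the scatter is expected. The expected change is a 1.0-fold lower number from compound 3 to compound 4 (0.01 log units; within the scatter). The estimated value for compound 4 is 5000 nM, with an expected range from 2300 nM to 10000 nM.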

Compound 4, half-maximal inhibitory concentration: 6100 nM
Compound 4: middle estimate off by 1.2-fold (0.09 log units), on the low side; the measured number falls inside the stated range.
By their numbers in this assay, from the lowest: compounds 2, 3 and 4 (each within the scatter of the next). At a limit, above all of these: compound 1.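

In this assay, methoxy in place of methyl on the aromatic carbon gives a 1.2-fold higher number from compound 3 to compound 4 (0.08 log units; within the scatter), the first step shown with a measured number at both ends. The swap brings in an oxygen, counted as a hydrogen-bond acceptor, yet the two numbers stay within the scatter of each other, so this position on this core accepts both groups with no readable difference in this assay. The earlier step on an aromatic ring had a limit at one end, held by compound 1, so it gave no exact size: the limit of > 10000 nM in this assay, at which 1 of the 4 values shown sits.

The compounds shown leave open whether any group at this place can move the number beyond the scatter on the core of compound 3, for example an amine, a carboxylic acid or a longer chain such as ethoxy. They also leave open how the bare ring with hydrogen at this place reads on this core, and whether chloro, seen here only on the core of compound 2, would give a similar number on the core of compound 3.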